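Removing 3-methylbut-2-en-1-yl from compound 1

This account rests on a few compounds, and the source may have more. Where it says the series, first, only, none or still open, it means among the compounds named here.

Compound 1 `COc1cc(C2Oc3cc(-c4oc5cc(OCC=C(C)C)cc(O)c5c(=O)c4O)ccc3OC2CO)ccc1OCC=C(C)C` gives 138000 nM
Compound 2 `CCOC(=O)COc1cc(O)c2c(=O)c(O)c(-c3ccc4c(c3)OC(c3ccc(OCC(=O)OCC)c(OC)c3)C(CO)O4)oc2c1` gives 116000 nM
Compound 3 `CCN(CC)C(=O)COc1cc(O)c2c(=O)c(O)c(-c3ccc4c(c3)OC(c3ccc(OCC(=O)N(CC)CC)c(OC)c3)C(CO)O4)oc2c1` gives 59900 nM

Among the compounds with values here, all three values come from a functional assay for inhibition, read by spectrophotometry, with a stated time of 10 min (on this read-out higher numbers stand for an effect only at larger amounts of compound and lower numbers for an effect already at smaller amounts), and no measured pair differs in one place only. Compound 1 (138000 nM) stands at the high end of the three numbers, within the scatter of compound 2 (116000 nM), while compound 3 (59900 nM) lies lower, beyond the scatter. Compound 4 `COc1cc(C2Oc3cc(-c4oc5cc(OCC=C(C)C)cc(O)c5c(=O)c4O)ccc3OC2CO)ccc1O` differs from compound 1 by one change hydrogen in place of 3-methylbut-2-en-1-yl on an oxygen on an aromatic ring that puts hydrogen in place of 3-methylbut-2-en-1-yl on an oxygen on an aromatic ring. Within the data shown here, no measured step shows this change, so the expectation rests only on the narrow spread of the three values, from compound 3 (59900 nM) to compound 1 (138000 nM). The expected step is a 1.7-fold lower number from compound 1 to compound 4 (0.24 log units; within the scatter) and it points to a lower number without leaving the scatter. The estimate for compound 4 is 80000 nM with 30000 nM to 200000 nM as the expected range.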

Compound 4, half-maximal effective concentration: 137000 nM
The estimate for compound 4 lay 1.7-fold (0.23 log units) below the measured number; low and high end bracket the measured number.
By their numbers in this assay, from the lowest: compounds 3, 2, 4 and 1 (each within the scatter of the next, the first and the last beyond it).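

In this assay, within the data shown here, hydrogen in place of 3-methylbut-2-en-1-yl on an oxygen on an aromatic ring gives a 1.0-fold lower number from compound 1 to compound 4 (0.00 log units; within the scatter) and is the first change read in one place alone. At this position, (3-methylbut-2-en-1-yl)oxy and hydroxy cannot be told apart on this read-out. No supporting data explain this result.

Open, going by these compounds, is whether an amine or a carboxylic acid on a short chain at this oxygen would shift the number. On these data alone, the second 3-methylbut-2-en-1-yl on the core also remains untested as a single change.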